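This account rests on a few compounds, and the source may have more. Where it says the series, first, only, none or still open, it means among the compounds named here.

Measured compounds in a functional assay on HepG2 cells (Homo sapiens) for cytotoxicity, read by MTT assay, with a stated time of 48 h; on this read-out lower numbers stand for stronger inhibition and higher numbers for weaker inhibition:

compound 1 `COc1cc(C(=O)C2Sc3nnc(-c4cc(OC)c(OC)c(OC)c4)n3NC2c2ccco2)cc(OC)c1OC` – only a limit, > 100000 nM
compound 2 `COc1cc(-c2nnc3n2NC(c2ccco2)C(C(=O)c2cccs2)S3)cc(OC)c1OC` – 64100 nM
compound 3 `COc1cc(-c2nnc3n2NC(c2ccco2)C(C(=O)c2ccc(Cl)cc2)S3)cc(OC)c1OC` – 78600 nM

Compound 3 holds the higher of the two numbers, with compound 2 nearest: a 1.2-fold higher number from compound 2 to compound 3 (0.09 log units; within the scatter). The other two steps start from the limit of compound 1 (the limit of > 100000 nM in this assay, at which 1 of the 3 values shown sits), so an at least 1.5-fold lower number from compound 1 to compound 2 (0.19 log units; that floor lies within the scatter) and an at least 1.2-fold lower number from compound 1 to compound 3 (0.10 log units; that floor lies within the scatter) give only floors, and both floors sit within the scatter. All three measured steps swap the whole aryl group on the carbonyl carbon; none of them alters a single substituent on that ring.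

Compound 4 `COc1cc(-c2nnc3n2NC(c2ccco2)C(C(=O)c2ccc(F)cc2)S3)cc(OC)c1OC` differs from compound 3 by fluoro in place of chloro on an aromatic carbon. Going by the values given here, no measured step bears directly on this change; the closest comparison, compound 2 against compound 3, shows that even a different ring on the carbonyl carbon moved this assay by a 1.2-fold higher number from compound 2 to compound 3 (0.09 log units; within the scatter). The step of a 1.0-fold higher number from compound 3 to compound 4 (0.01 log units; within the scatter) is therefore expected to stay within the scatter, in no set direction. Compound 4 is estimated at 80000 nM, with a range from 35000 nM to 180000 nM, and a fair chance that the assay again returns only a limit.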

Compound 4, half-maximal inhibitory concentration: > 100000 nM
Compound 4: only a limit was reported (the forecaster's own chance of this, stated with the estimate: 30%); middle value at least 1.2-fold (0.09 log units) away from the limit.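

Fluoro in place of chloro on the 4-chlorophenyl group is the first change in the series that keeps the ring on the carbonyl carbon and alters only its substituent, and in this assay it gives no more than a floor: an at least 1.2-fold higher number from compound 3 to compound 4 (0.10 log units; that floor lies within the scatter). Against the thiophen-2-yl compound the reading is also only a floor, an at least 1.5-fold higher number from compound 2 to compound 4 (0.19 log units; that floor lies within the scatter), so neither step shows a change at this position beyond the scatter. Compound 1 and compound 4 form a pair with no readable step, and the series now presses against the top of the range of the assay: the limit of > 100000 nM in this assay, at which 2 of the 4 values shown sit.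

Open, going by these compounds, is whether fluoro and chloro at this place differ at all in this assay. Also open, on these data alone, is what an amine or a carboxylic acid on that ring, in place of the halogen, would do to the number.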